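This account rests on a few compounds, and the source may have more. Where it says the series, first, only, none or still open, it means among the compounds named here.

Three compounds have been measured in a functional assay on BT-483 cells (Homo sapiens) for cytotoxicity, read by MTT assay, with a stated time of 24 h; a lower number here means a stronger inhibitor, a higher number a weaker inhibitor:

compound 1, `CCNc1cc(-c2ccc(NC(=O)Nc3cccc(Cl)c3)cc2C)ccn1`: 16600 nM
compound 2, `CCNc1cc(-c2ccc(NC(=O)Nc3ccc(C(F)(F)F)cc3)cc2C)ccn1`: 19700 nM
compound 3, `CCCNc1cc(-c2ccc(NC(=O)Nc3cccc(Cl)c3)cc2C(F)(F)F)ccn1`: 18500 nM

Compound 2 differs from compound 1 by 4-(trifluoromethyl)phenyl in place of 3-chlorophenyl on an amide-type nitrogen, and this change gave a 1.2-fold higher number from compound 1 to compound 2 (0.07 log units; within the scatter). Compound 3 carries a different core; how its core differs from that of compound 1 is not broken down here, and its value sits among those of compound 1 and compound 2, within the scatter of both.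

Compound 4, `CCCNc1cc(-c2ccc(NC(=O)Nc3ccc(C(F)(F)F)cc3)cc2C(F)(F)F)ccn1`, is not yet measured. It differs from compound 3 by 4-(trifluoromethyl)phenyl in place of 3-chlorophenyl on an amide-type nitrogen, the same change made at the same place as before, so that this change occurs twice among these compounds. For this assay a step of the same small size is expected, a 1.2-fold higher number from compound 3 to compound 4 (0.08 log units; within the scatter), because the earlier instance of this change gave a 1.2-fold higher number from compound 1 to compound 2 (0.07 log units; within the scatter). Compound 4 is therefore estimated at 22000 nM, with a range from 11000 nM to 44000 nM.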

Compound 4, half-maximal inhibitory concentration: 18800 nM
Estimate against measurement, compound 4: 1.2-fold (0.07 log units) above, within the range that was stated.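

In this assay, placing 4-(trifluoromethyl)phenyl instead of 3-chlorophenyl on the amide-type nitrogen gave a 1.0-fold higher number from compound 3 to compound 4 (0.01 log units; within the scatter). The two instances of this change agree: the same change on two cores in this assay, a 1.2-fold higher number (0.07 log units; within the scatter) from compound 1 to compound 2 and a 1.0-fold higher number (0.01 log units; within the scatter) from compound 3 to compound 4, 1.2-fold (0.07 log units) apart, within the scatter of two such steps. This shows that the change carried over between these two cores without a step beyond the scatter, but both steps are small, so it does not show that a larger step would carry over or that a third core would behave alike.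

The compounds shown leave open how the differences between the two cores act individually. They also leave open whether a carboxylic acid or an amine in place of the chlorine or the trifluoromethyl would shift the number in this assay.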